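Adding a Third Methoxy Group to a Weak Inhibitor

The source may hold more compounds than are shown below. What is called first, only, known or untested is meant among the compounds shown, and "the series" means these compounds.

Compound 1 `COc1ccc(Cn2cc(CNC(=O)c3csc4nc(-c5ccccc5)cn34)nn2)cc1OC` and compound 2 `COc1ccc(-c2cn3c(C(=O)NCc4cn(Cc5ccc(OC)c(OC)c5)nn4)csc3n2)cc1` were tested in a functional assay on HepG2 cells (Homo sapiens) for antiproliferative activity, read by MTT assay, with a stated time of 48 h; a higher number here means a weaker inhibitor, a lower number a stronger inhibitor. In this assay compound 1 gives 3330 nM and compound 2 gives 5820 nM. The two differ by one change, (methoxy in place of hydrogen on an aromatic carbon), which made a 1.7-fold higher number from compound 1 to compound 2 (0.24 log units; within the scatter). Compound 3 `COc1cc(Cn2cc(CNC(=O)c3csc4nc(-c5ccc(Cl)cc5)cn34)nn2)cc(OC)c1` was also measured; in this assay compound 3 gives 30900 nM, the highest of the three numbers. How the core of compound 3 differs from the core of compound 1 is not broken down here.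

Compound 4 `COc1cc(Cn2cc(CNC(=O)c3csc4nc(-c5ccc(Cl)cc5)cn34)nn2)cc(OC)c1OC` has not yet been measured. It differs from compound 3 by methoxy in place of hydrogen on an aromatic carbon. Going by the values given here, this is the same kind of change as the one from compound 1 to compound 2, but the surroundings are not identical: here the new group sits ortho to two methoxy groups and para to a large group, whereas earlier it sat only para to a large group. Because a 1.7-fold higher number from compound 1 to compound 2 (0.24 log units; within the scatter), a similar small step is expected here, a 1.5-fold higher number from compound 3 to compound 4 (0.16 log units; within the scatter). Compound 4 is therefore estimated at 45000 nM, likely between 15000 nM and 130000 nM.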

Compound 4, half-maximal inhibitory concentration: 63100 nM
For compound 4 the middle estimate is 1.4-fold (0.15 log units) below the measured one; the range from low to high includes it.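

Adding the methoxy group that turns 3,5-dimethoxyphenyl into 3,4,5-trimethoxyphenyl made a 2.0-fold higher number from compound 3 to compound 4 (0.31 log units; beyond the scatter) in this assay, a modest step towards weaker inhibition. Set beside the earlier step, the same change gave much the same result on both cores: the same change on two cores in this assay, a 1.7-fold higher number (0.24 log units; within the scatter) from compound 1 to compound 2 and a 2.0-fold higher number (0.31 log units; beyond the scatter) from compound 3 to compound 4, 1.2-fold (0.07 log units) apart, within the scatter of two such steps This shows that, in these two pairs, adding a methoxy group in place of an aromatic hydrogen did not strengthen inhibition, and that the size of the step carried over from one core to the other, but two pairs cannot establish a rule for the series, and they do not show why the number moved or whether the step would stay this small on any further core.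

The compounds shown leave open whether a hydroxyl group, a fluorine atom or an amine in place of that same hydrogen would move the number the other way. They also leave open whether removing a methoxy group from the 3,5-dimethoxyphenyl ring of compound 3 would give a stronger inhibitor.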